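This account rests on a few compounds, and the source may have more. Where it says the series, first, only, none or still open, it means among the compounds named here.

Series notes. In an assay for binding affinity to Alpha-1B adrenergic receptor (Homo sapiens) (a lower number here means a stronger inhibitor, a higher number a weaker inhibitor), compound 1 `O=c1c2ccccc2c(Cc2ccc(Cl)cc2)nn1C1CCCN(Cc2ccc(OCCCN3CCCCCC3)cc2)CC1` gives 126 nM. Compound 2 `CN1CCC[C@@H]1Cn1nc(CC2CCCCC2)c2ccccc2c1=O` carries a smaller group on the ring nitrogen and a saturated ring on the chain carbon. In this assay compound 2 gives > 1990 nM, which is a limit of the assay and not a number; it sits at the limit of > 1990 nM in this assay, at which 1 of the 2 values shown sits. Compound 3 `COc1cccc(Cc2nn(C[C@H]3CCCN3C)c(=O)c3ccccc23)c1` differs from compound 2 by 3-methoxyphenyl in place of cyclohexyl on a saturated chain carbon bound to an aromatic carbon. Among the measured compounds shown here, with no comparable pair measured, the expected step of an at least 1.3-fold lower number from compound 2 to compound 3 (0.12 log units; that floor lies within the scatter) is toward stronger binding but uncertain in size. Compound 3 is estimated at 1500 nM, within 300 nM to 6000 nM.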

Compound 3, inhibition constant: > 1990 nM
Compound 3 was reported as a limit; the forecaster's own chance of this, stated with the estimate: 45%; middle value at least 1.3-fold (0.12 log units) from the limit.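

Compound 2 and compound 3 both stand as limits of this assay, not numbers, so no step can be read between them: the limit of > 1990 nM in this assay, at which 2 of the 3 values shown sit. Going by these compounds, how 3-methoxyphenyl in place of cyclohexyl changes binding remains open.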